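Pyridyl for fluorophenyl on an amide nitrogen

A few compounds are considered here, and "the series" means these few. Any claim that something is new, unique, unknown or untested is made for them only; others in the source may bear on it.

Compound 1, `Cc1ccccc1N(C)C(=O)c1ccc(-c2ccc(O)c(F)c2)o1`, gives 11 nM in an assay on cytosol from placenta for inhibition of 17-beta-hydroxysteroid dehydrogenase type 1 (Homo sapiens), read by HPLC, with a stated time of 10 min, in the presence of a further agent that is not named here; a lower number here means a stronger inhibitor, a higher number a weaker inhibitor.
Compound 2, `Cc1cc(F)ccc1N(C)C(=O)c1ccc(-c2ccc(O)cc2)o1`, gives 23 nM in this assay.

Of the two measured compounds, compound 2 has the higher number, which here marks the weaker inhibitor. Its nearest neighbour is compound 1, and the gap between them lies beyond the usual scatter. The two compounds differ in more than one place, so only their two values can be set side by side, and no single change is tied to that gap.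

Compound 3, `Cc1ccncc1N(C)C(=O)c1ccc(-c2ccc(O)cc2)o1`, has not yet been measured. It differs from compound 2 in one place: 4-methylpyridin-3-yl in place of 4-fluoro-2-methylphenyl on an amide-type nitrogen. The ring on the amide-type nitrogen keeps a methyl group, loses its fluorine, and gains a ring nitrogen that is a hydrogen-bond acceptor. Going by the values given here, no measured pair shows what such a swap does here, so any expectation rests on little. A modest weakening is expected, a 1.7-fold higher number from compound 2 to compound 3 (0.24 log units; within the scatter), though a step within the scatter would not surprise. Compound 3 is therefore estimated at about 40 nM in this assay, within a range from 12 nM to 130 nM.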

Compound 3, half-maximal inhibitory concentration: 260 nM
Compound 3: the middle estimate sits 6.5-fold (0.81 log units) below what was measured, outside the stated range (above it).
By their numbers in this assay, from the lowest: compound 1; then compound 2; then compound 3.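

In this assay, the ring on the amide-type nitrogen proves to matter a great deal: 4-methylpyridin-3-yl in place of 4-fluoro-2-methylphenyl gives an 11-fold higher number from compound 2 to compound 3 (1.05 log units; beyond the scatter). This is the first change at a single place among these compounds, so it is the first result that ties a shift in potency to one position, and here that shift is a clear loss. The two rings look much alike on paper, since both are six-membered and aromatic and both carry a methyl group, so a close resemblance between rings does not ensure similar potency at this position; nothing measured here explains the loss.

The change also does two things at once, removing the fluorine and bringing in a ring nitrogen, and the compounds shown do not separate these two parts, so the share of each in the loss stays unknown. On these data alone, a phenyl ring with chlorine in place of the fluorine, or a pyrimidine ring carrying the same methyl group, would probe this position further, and how either would behave remains open.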